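This account rests on a few compounds, and the source may have more. Where it says the series, first, only, none or still open, it means among the compounds named here.

In an ADME assay on BJ cells (Homo sapiens), read by MTT assay, with a stated time of 72 h (a lower number here means a stronger inhibitor, a higher number a weaker inhibitor), four closely related nucleoside compounds are compared, three of them already measured. Compound 1, `Cc1ncnc2c1c(I)cn2[C@@H]1O[C@H](CO)[C@@H](O)[C@H]1O`, gives only a limit of the assay rather than a number: > 100000 nM, which is the limit of > 100000 nM in this assay, at which 1 of the 3 values shown sits. Compound 2, `Cc1ncnc2c1c(-c1ccoc1)cn2[C@@H]1O[C@H](CO)[C@@H](O)[C@H]1O`, gives 89200 nM. The change between them is furan-3-yl in place of iodo on an aromatic carbon, and this step, an at least 1.1-fold lower number from compound 1 to compound 2 (0.04 log units; that floor lies within the scatter), is a small one that rests on a limit at its start.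

Among the measured compounds shown here, compound 3, `Cc1nc(N)c2c(I)cn([C@@H]3O[C@H](CO)[C@@H](O)[C@H]3O)c2n1`, gives 24600 nM, the lowest of the two numbers so far; the difference between its core and the core of compound 1 is not broken down here.

Compound 4, `Cc1nc(N)c2c(-c3ccoc3)cn([C@@H]3O[C@H](CO)[C@@H](O)[C@H]3O)c2n1`, has not yet been measured. For the measured compounds named here, it differs from compound 3 by furan-3-yl in place of iodo on an aromatic carbon, the same change as the one from compound 1 to compound 2, made at a place described in the same words. Going by the values given here, since the only measured example of this change, an at least 1.1-fold lower number from compound 1 to compound 2 (0.04 log units; that floor lies within the scatter), shows little movement beyond what a limit allows, the expected step from compound 3 to compound 4 is estimated to be modest as well, a 1.6-fold lower number from compound 3 to compound 4 (0.21 log units; within the scatter). On that basis, compound 4 is expected to give about 15000 nM, estimated to lie between 5000 nM and 50000 nM. The measured value of compound 4 is given next.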

Compound 4, half-maximal inhibitory concentration: > 100000 nM
Compound 4: a limit, no number; the forecaster's own chance of this, stated with the estimate: 10%; middle value at least 6.6-fold (0.82 log units) from the limit.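

Putting furan-3-yl in place of iodo on an aromatic carbon did not act alike on the two cores: the same change on two cores in this assay, an at least 1.1-fold lower number (0.04 log units; that floor lies within the scatter) from compound 1 to compound 2 and an at least 4.0-fold higher number (0.60 log units; beyond the scatter) from compound 3 to compound 4, at least 4.5-fold (0.65 log units) apart, beyond the scatter of two such steps

The step on the core of compound 1 was therefore a poor guide to the new step, an at least 4.0-fold higher number from compound 3 to compound 4 (0.60 log units; beyond the scatter), so in this series a result for this change on one core cannot simply be carried over to the other. This does not show how large either step really is, nor does it give a general rule, as there is only one pair for each core and each pair has one member at a limit of the assay rather than at a number: the limit of > 100000 nM in this assay, at which 2 of the 4 values shown sit.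

The compounds shown leave open whether the rise on the core of compound 3 belongs to furan-3-yl alone, or would also appear with another group in place of iodo, such as a phenyl ring, a thiophene ring, an amine or a short chain like ethyl. As far as these compounds go, it also remains open which of the differences between the two cores goes with the different outcome, since the two cores differ in more than one place.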